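The source may hold more compounds than are shown below. What is called first, only, known or untested is meant among the compounds shown, and "the series" means these compounds.

In a functional assay on the whole organism (strain CD1) for inhibition, with Mus musculus as the target, with stated times of 15 min and 20 min, at a dose of 10 mg/kg by the subcutaneous route (a lower number here means less inhibition, a higher number more inhibition at the dose given (going by the name of the read-out)), three compounds have been measured so far:

compound 1, `CCNC(=O)/C(C#N)=C/c1ccoc1`, gives 31%;
compound 2, `N#C/C(=C\c1ccoc1)C(=O)NC1CCCCC1`, gives 0%;
compound 3, `CCNC(=O)/C(C#N)=C/c1cc2ccccc2[nH]1`, gives 45%.

Compound 1 and compound 2 share a core and differ in one place: cyclohexyl in place of ethyl on an amide-type nitrogen. That change made a number 31 percentage points lower from compound 1 to compound 2 (beyond the scatter). Compound 3 carries a different core; how the two cores differ is not broken down here, but in this assay compound 3 gives the highest of the three numbers, and its distances to compound 1 and to compound 2 both lie beyond the scatter. Compound 4, `N#C/C(=C\c1cc2ccccc2[nH]1)C(=O)NC1CCCCC1`, is not yet measured. It stands to compound 3 as compound 2 stands to compound 1: cyclohexyl in place of ethyl on an amide-type nitrogen. Because the same change gave a number 31 percentage points lower from compound 1 to compound 2 (beyond the scatter), a drop of the same kind is expected here. The step from compound 3 to compound 4 is estimated as a number 35 percentage points lower from compound 3 to compound 4 (beyond the scatter). Going by the values given here, with only one earlier example of this change, and that on another core, the expectation is loose. Compound 4 is expected to give 10%, likely between 0% and 30%.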

Compound 4, a percentage reported as inhibition, in the whole organism at one dose (the size of the read-out at that dose, not a potency): 45%
Compound 4: middle estimate off by 35 percentage points, on the low side; measured number above the stated range.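

In this assay, cyclohexyl in place of ethyl on an amide-type nitrogen on the core of compound 3 gives no change at the digits printed from compound 3 to compound 4 (within the scatter). The size of this change therefore does not carry from the core of compound 1 to the core of compound 3; the effect of the change depends on the core it is made on: the same change on two cores in this assay, a number 31 percentage points lower (beyond the scatter) from compound 1 to compound 2 and no change at the digits printed (within the scatter) from compound 3 to compound 4, 31 percentage points apart, beyond the scatter of two such steps This shows only that the outcome differs between these two pairs, and it does not show why they differ, nor what the change would do on any further core, since each core offers a single pair.

The compounds shown leave open how a longer chain, or a chain ending in an amine, on the amide-type nitrogen would behave on either core. They also leave open whether the nitrile, which all four compounds carry, could give way to a carboxylic acid, and whether the contrast between the two cores would then remain.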